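The source may report more compounds than this note shows. Statements on the series, on what has been measured and on what is new or still open speak of the compounds shown alone.

Working notes on the series. Two compounds have numbers in an assay on isolated protein for inhibition of Rho-associated protein kinase 2 (Homo sapiens), read by scintillation counting, radiometric assay and 33P incorporation, with a stated time of 40 min, in the presence of a further agent that is not named here; on this read-out lower numbers stand for stronger inhibition and higher numbers for weaker inhibition. Compound 1, `CN(C)c1ccc(C(=O)Nc2cccc(NC(=O)COc3ccc4c(c3)CCC(=O)N4)c2)cc1`, gives 9970 nM in this assay. Compound 2, `CCc1ccc(C(=O)Nc2cccc(NC(=O)COc3ccc4c(=O)ccoc4c3)c2)cc1`, gives 24 nM in this assay. Compound 2 therefore holds the lowest of the two numbers; its nearest neighbour, compound 1, sits at a much higher number, a gap stated to lie beyond the scatter of repeated measurements. Among the measured compounds shown here, compound 1 and compound 2 differ in more than one place, so no single step between measured compounds can be read off, and nothing is known yet about the weight of any single change within this pair.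

Compound 3, `O=C(COc1ccc2c(=O)ccoc2c1)Nc1cccc(NC(=O)c2ccc(OC(F)(F)F)cc2)c1`, is the next one to be measured in this assay. It differs from compound 2 in one place: trifluoromethoxy in place of ethyl on an aromatic carbon, on an aromatic carbon of a six-membered aromatic ring of carbon only, para to a large group. For the measured compounds named here, no measured step of this kind exists. The expectation for the step from compound 2 to compound 3 is therefore a small one, a 1.3-fold higher number from compound 2 to compound 3 (0.10 log units; within the scatter), not beyond the scatter in either direction. Compound 3 is estimated at 30 nM in this assay, within a range of 10 nM to 100 nM.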

Compound 3, half-maximal inhibitory concentration: 77 nM
For compound 3 the middle estimate is 2.6-fold (0.41 log units) below the measured one, and the stated range covers the measured number.
By their numbers in this assay, from the lowest: compound 2; then compound 3; then compound 1.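

The change of trifluoromethoxy in place of ethyl on an aromatic carbon, para to a large group, gives the series its first readable single-place step in this assay: a 3.2-fold higher number from compound 2 to compound 3 (0.51 log units; beyond the scatter) is modest but beyond the scatter. This position is therefore not indifferent to the group it carries, and here the group with 5 heavy atoms and 1 hydrogen-bond acceptor goes with weaker inhibition than the ethyl group with 2 heavy atoms and no acceptor. No available evidence accounts for the size or the direction of this step.

The compounds shown leave open which part of the entering group goes with the higher number, a question that methoxy and trifluoromethyl at the same place would help to separate, and whether a longer chain such as propyl, an amine or a carboxylic acid would be accepted there. They also leave open whether the same change would give a step of similar size on the core of compound 1, since a single pair supplies this step.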